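Working notes: methoxy to hydrogen and the cytotoxic read-out

This account rests on a few compounds, and the source may have more. Where it says the series, first, only, none or still open, it means among the compounds named here.

Measured compounds, with their values in a functional assay on HOP-62 cells (Homo sapiens) for cytotoxicity, read by sulforhodamine B assay, with a stated time of 48 h, tested at 0.01 uM; on this read-out higher numbers stand for a weaker effect at the one concentration tested and lower numbers for a stronger effect:
compound 1, `COc1cc(-c2cc(/C=C/C(=O)c3ccc(N)cc3)[nH]n2)cc(OC)c1OC`, gives 83%
compound 2, `COc1ccc(-c2cc(/C=C/C(=O)c3ccc(N)cc3)[nH]n2)cc1OC`, gives 83%
compound 3, `COc1cc(C(=O)/C=C/c2cc(-c3cc(OC)c(OC)c(OC)c3)n[nH]2)cc(OC)c1OC`, gives 97%

Compound 1 and compound 2 share a core and differ in one place, (hydrogen in place of methoxy on an aromatic carbon). The step in this assay is no change at the digits printed from compound 1 to compound 2 (within the scatter), so the removal of this methoxy left the read-out where it was.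

Compound 3 stands on a different core; the difference between the two cores is not broken down here. In this assay compound 3 gives the highest of the three numbers, and its distance to compound 1 and to compound 2 lies beyond the scatter, so compound 3 shows the weakest effect of the three at the concentration tested.

Compound 4, `COc1ccc(-c2cc(/C=C/C(=O)c3cc(OC)c(OC)c(OC)c3)[nH]n2)cc1OC`, is not yet measured. It differs from compound 3 by hydrogen in place of methoxy on an aromatic carbon. The place line of this change reads word for word as that of the change from compound 1 to compound 2, so it is the same change, made on the other core.

For compound 4 the step of a number 2 percentage points lower from compound 3 to compound 4 (within the scatter) is expected to be small, because the same change gave no change at the digits printed from compound 1 to compound 2 (within the scatter) on the first core. On that basis compound 4 is estimated at 95% in this assay, with a likely range from 84% to 106%. This rests on a single measured pair; a different response on the core of compound 3 cannot be ruled out.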

Compound 4, a percentage reported as activity, at one concentration (the size of the read-out at that concentration, not a potency): 92%
For compound 4 the middle estimate is 3 percentage points above the measured one, within the range that was stated.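

In this assay, taking off this methoxy on the core of compound 3 gave a number 5 percentage points lower from compound 3 to compound 4 (within the scatter), so on this core too the step stays inside the usual variation of the read-out. Set side by side, the two steps do not differ, and for these two pairs the change carries over from one core to the other: the same change on two cores in this assay, no change at the digits printed (within the scatter) from compound 1 to compound 2 and a number 5 percentage points lower (within the scatter) from compound 3 to compound 4, 5 percentage points apart, within the scatter of two such steps. This shows only that hydrogen in place of methoxy, at this place on the ring, gave no step beyond the scatter on either core at the one concentration tested; it does not show that the same would hold at other concentrations, in other cells or on a third core, and two pairs are too few to make a rule of it.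

Open, as far as these compounds go, is whether a different group at this place, such as hydroxyl, fluorine, chlorine or a longer chain like ethoxy, would also leave the read-out unmoved on both cores. Also open, from the compounds shown here alone, is what happens when a methoxy on the other aromatic ring of compound 4 gives way to hydrogen, or when more than one methoxy leaves at once.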